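Series notes: pyridyl isomer swap on the core of compound 3

The source may hold more compounds than are shown below. What is called first, only, known or untested is meant among the compounds shown, and "the series" means these compounds.

Compound 3 `Clc1ccc(-c2cc(-c3cccnc3)nc(-c3ccsc3)c2)o1` gives 0% in an assay on isolated protein for inhibition of DNA topoisomerase 1 (Homo sapiens), tested at 100 uM (a higher number here means a stronger effect of the compound at the concentration tested, a lower number a weaker effect), the lowest of the three numbers. Compound 1 `Clc1ccc(-c2cc(-c3ccsc3)nc(-c3ccco3)c2)o1` gives 8.2% in this assay, a gap within the scatter, while compound 2 `Clc1ccc(-c2cc(-c3ccc(Cl)o3)cc(-c3ccsc3)n2)cc1` gives 29.8%, set apart by the step of a number 29.8 percentage points lower from compound 2 to compound 3 (beyond the scatter). Compound 4 `Clc1ccc(-c2cc(-c3ccsc3)nc(-c3ccccn3)c2)o1` differs from compound 3 by pyridin-2-yl in place of pyridin-3-yl on an aromatic carbon; the two have the same atoms, joined differently. Among the measured compounds shown here, no measured step exchanges one pyridyl isomer for another: the steps of a number 8.2 percentage points lower from compound 1 to compound 3 (within the scatter) and a number 29.8 percentage points lower from compound 2 to compound 3 (beyond the scatter) bring pyridin-3-yl in for other rings and say nothing about pyridin-2-yl. For the measured compounds named here, with no bearing step, the expected change a number 5 percentage points higher from compound 3 to compound 4 (within the scatter) is estimated as none beyond the scatter. Compound 4 is therefore expected to give 5%, within a range from 0% to 20%.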

Compound 4, a percentage reported as inhibition, at one concentration (the size of the read-out at that concentration, not a potency): 0%
Estimate against measurement, compound 4: 5 percentage points above; measured number inside the range.
By their numbers in this assay, from the lowest: compounds 3, 4 and 1 (each within the scatter of the next); then compound 2.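

In this assay, among the compounds shown here, the first direct exchange of pyridyl isomers at this position gives no change at the digits printed from compound 3 to compound 4 (within the scatter) and so does not separate pyridin-2-yl from pyridin-3-yl. Pyridin-2-yl matches the earlier pattern for pyridin-3-yl against the other rings, with a number 29.8 percentage points lower from compound 2 to compound 4 (beyond the scatter) for 4-chlorophenyl and a number 8.2 percentage points lower from compound 1 to compound 4 (within the scatter) for furan-2-yl. No measurement at hand explains why the two isomers read alike.

Still open, as far as these compounds go, is whether a carboxylic acid, a dimethylamino group or a methoxy group on the pyridin-2-yl ring would shift the reading of compound 4.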